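Removing the oxirane from the side chain on the shared core

The source may hold more compounds than are shown below. What is called first, only, known or untested is meant among the compounds shown, and "the series" means these compounds.

Compound 2 `N#Cc1c(-c2ccc(Cl)cc2)cc(-c2ccc(Cl)cc2)n(CC2CO2)c1=O` gives 5 ug/mL in a functional assay on MCF7 cells (Homo sapiens) for cytotoxicity, read by sulforhodamine B assay, with a stated time of 48 h (a lower number here means a stronger inhibitor, a higher number a weaker inhibitor), the lowest of the two numbers in hand and beyond the scatter from its nearest neighbour; compound 1 `C#CCn1c(-c2ccc(Cl)cc2)cc(-c2ccc(Cl)cc2)c(C#N)c1=O` gives 16.7 ug/mL in this assay, while compound 3 `N#CCn1c(-c2ccc(Cl)cc2)cc(-c2ccc(Cl)cc2)c(C#N)c1=O` is reported as "not active" (no number reported) in this assay, without a number. Compound 4 `CCn1c(-c2ccc(Cl)cc2)cc(-c2ccc(Cl)cc2)c(C#N)c1=O` carries methyl in place of oxiran-2-yl on a saturated chain carbon bound to an aromatic nitrogen. For the measured compounds named here, the one measured step bears on this change in the opposite direction: a 3.3-fold lower number from compound 1 to compound 2 (0.52 log units; beyond the scatter). Compound 3 gives no number at all. Both observations point toward a weaker inhibitor once the oxiran-2-yl is gone, so compound 4 is expected to sit nearer compound 1. The step of a 4.0-fold higher number from compound 2 to compound 4 (0.60 log units; beyond the scatter) is therefore expected. The estimate for compound 4 in this assay is 20 ug/mL, with a range from 8 ug/mL to 60 ug/mL.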

Compound 4, half-maximal inhibitory concentration: 19.7 ug/mL
Compound 4: the middle estimate sits 1.0-fold (0.01 log units) above what was measured; the measured number falls inside the stated range.
By their numbers in this assay, from the lowest: compound 2; then compounds 1 and 4 (each within the scatter of the next).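

In this assay, the change from oxiran-2-yl to methyl on a saturated chain carbon bound to an aromatic nitrogen gives a 3.9-fold higher number from compound 2 to compound 4 (0.60 log units; beyond the scatter) and so confirms the gap with a second group, not only with ethynyl. Methyl and ethynyl at this place do not separate, with a 1.2-fold higher number from compound 1 to compound 4 (0.07 log units; within the scatter) and so only compound 2 stands apart among the three numbers. No measurement on hand accounts for this difference.

Going by these compounds, whether an amine, a carboxylic acid or a longer chain at this place would stand with compound 2 or with compound 1 and compound 4 stays open. Also open, on these data alone, is whether another three-membered ring, such as cyclopropyl, would keep the number of compound 2.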